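The source may report more compounds than this note shows. Statements on the series, on what has been measured and on what is new or still open speak of the compounds shown alone.

Compound 1 `NC(=O)c1cccc(Cn2cc(-c3ccc4cn[nH]c4c3)ccc2=O)c1`: 106 nM in an assay for inhibition of MAP kinase-interacting serine/threonine-protein kinase 2 (Homo sapiens), read by luminescence and ADP-Glo, with a stated time of 2 h; on this read-out higher numbers stand for weaker inhibition and lower numbers for stronger inhibition
Compound 2 `O=C(N1CCOCC1)n1cc(-c2ccc3cn[nH]c3c2)ccc1=O`: > 2000 nM in this assay, a limit, not a number
Compound 3 `O=c1ccc(-c2ccc3cn[nH]c3c2)cn1Cc1cccc(Cl)c1`: 40 nM in this assay

Among the two numbers in this assay, compound 3 holds the lowest; its nearest neighbour is compound 1, and the step of a 2.7-fold lower number from compound 1 to compound 3 (0.42 log units; beyond the scatter) separates them. Compound 2 sits at the limit of the assay, (the limit of > 2000 nM in this assay, at which 1 of the 3 values shown sits), so the step of an at least 50-fold lower number from compound 2 to compound 3 (1.69 log units; beyond the scatter) can only be given as a lower bound.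

Compound 4 `O=c1ccc(-c2ccc3cn[nH]c3c2)cn1Cc1ccc(Cl)c(Cl)c1` differs from compound 3 by chloro in place of hydrogen on an aromatic carbon. Among the measured compounds shown here, two measured steps touch the same region of the molecule. The step from compound 1 to compound 3, which exchanged one group on the benzyl ring for another, was modest. The step from compound 2 to compound 3, which replaced the whole substituent on the ring nitrogen, was large. Neither step adds a second chloro to a ring that already carries one, so the closest guide is the modest benzyl-ring step. A step of at most modest size in this assay, probably toward a lower number, is therefore expected, though it may stay within the scatter. Compound 4 is estimated at 25 nM, within 10 nM to 70 nM. This estimate corresponds to a step of a 1.6-fold lower number from compound 3 to compound 4 (0.20 log units; within the scatter).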

Compound 4, half-maximal inhibitory concentration: 97 nM
Compound 4: the middle estimate sits 3.9-fold (0.59 log units) below what was measured; measured number outside the range, above it.
By their numbers in this assay, from the lowest: compound 3; then compounds 4 and 1 (each within the scatter of the next). At a limit, above all of these: compound 2.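

Adding a chloro to the 3-chlorophenyl ring of compound 3, ortho to the chloro group already there and para to a large group, weakens inhibition in this assay, with a 2.4-fold higher number from compound 3 to compound 4 (0.38 log units; beyond the scatter). The earlier compounds shown here showed only what happens when the group on this ring, or the whole substituent on the ring nitrogen, is exchanged; this result shows that a ring carbon carrying only hydrogen in compound 3 is also sensitive, since the entry of one chlorine atom moves the number beyond the scatter. Nothing measured here explains why the 3,4-dichlorophenyl group gives this step.

As far as these compounds go, whether this step belongs to chloro in particular or would follow any group at this carbon stays open, and a fluoro, a methoxy or an amine in that place could separate the two. From the compounds shown here alone, it also remains open how much the chloro of compound 3 contributes by itself, which a comparison with the plain benzyl group carrying only hydrogen on its ring would show.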